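A few compounds are considered here, and "the series" means these few. Any claim that something is new, unique, unknown or untested is made for them only; others in the source may bear on it.

In a functional assay on HepG2 cells (Homo sapiens) for cytotoxicity, read by MTT assay, with a stated time of 48 h (a higher number here means a weaker inhibitor, a lower number a stronger inhibitor), compound 1 `COc1cc(-c2nnc3n2NC(c2ccco2)C(C(=O)c2ccc(Cl)cc2)S3)cc(OC)c1OC` gives 78600 nM. Compound 2 `COc1cc(-c2nnc3n2NC(c2ccco2)C(C(=O)c2cccc4ccccc24)S3)cc(OC)c1OC` gives 33900 nM in this assay, which is a 2.3-fold lower number from compound 1 to compound 2 (0.37 log units; beyond the scatter). For compound 3 `COc1cc(-c2nnc3n2NC(c2ccco2)C(C(=O)c2ccc(O)cc2)S3)cc(OC)c1OC` the read-out in this assay is only a limit of the assay, > 100000 nM. From compound 1 the change is an at least 1.2-fold higher number from compound 1 to compound 3 (0.10 log units; that floor lies within the scatter), and from compound 2 it is an at least 2.9-fold higher number from compound 2 to compound 3 (0.46 log units; beyond the scatter). Compound 4 `COc1cc(-c2nnc3n2NC(c2ccco2)C(C(=O)c2ccco2)S3)cc(OC)c1OC` differs from compound 3 in one place: furan-2-yl in place of 4-hydroxyphenyl on a carbonyl carbon. Going by the values given here, no measured step involves furan-2-yl, and all three measured compounds are weak inhibitors, so the change is expected to give a step of no more than the scatter, an at least 1.1-fold lower number from compound 3 to compound 4 (0.04 log units; that floor lies within the scatter). Compound 4 is therefore estimated at 90000 nM in this assay, with a range from 30000 nM to 250000 nM.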

Compound 4, half-maximal inhibitory concentration: > 100000 nM
Compound 4: no number, only a limit (the forecaster's own chance of this, stated with the estimate: 45%); middle value at least 1.1-fold (0.04 log units) from the limit.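

In this assay compound 4 gives only a limit, as compound 3 does, so the step between them cannot be read, and the scale is cut off at this carbonyl carbon: the limit of > 100000 nM in this assay, at which 2 of the 4 values shown sit. Furan-2-yl reaches that limit without the hydroxy group of compound 3. In place of naphthalen-1-yl it gives an at least 2.9-fold higher number from compound 2 to compound 4 (0.46 log units; beyond the scatter), while in place of 4-chlorophenyl it gives an at least 1.2-fold higher number from compound 1 to compound 4 (0.10 log units; that floor lies within the scatter), too small a floor to separate the two. From the compounds shown here alone, how far compounds 3 and 4 lie past the limit stays open. So does what cyclohexyl, or a phenyl carrying a carboxylic acid, would give here.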